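Hydroxy to trifluoromethyl on the sulfonyl ring: tolerance notes

The source may hold more compounds than are shown below. What is called first, only, known or untested is meant among the compounds shown, and "the series" means these compounds.

Measured so far, all in an ADME assay on HEK293 cells (Homo sapiens) for cytotoxicity, read by resazurin assay, with a stated time of 48 h; a higher number here means that more compound is tolerated, a lower number that less compound is tolerated:

compound 1 `O=S(=O)(Nc1ccc2oc(-c3ccccc3)nc2c1)c1cccc(C(F)(F)F)c1`: > 100000 nM, a limit of the assay and not a number.
compound 2 `O=S(=O)(Nc1ccc2oc(-c3ccccc3)nc2c1)c1cccc(O)c1`: > 100000 nM, again a limit, not a number.
compound 3 `O=S(=O)(Nc1ccc2oc(-c3ccccc3)nc2c1)c1ccccc1O`: 33000 nM.

Going by the values given here, compound 3 thus carries the only number in this assay; the other two values sit at the limit of > 100000 nM in this assay, at which 2 of the 3 values shown sit. Moving the hydroxy, (2-hydroxyphenyl in place of 3-hydroxyphenyl on a sulfonyl sulfur), gives an at least 3.0-fold lower number from compound 2 to compound 3 (0.48 log units; beyond the scatter). Exchanging the group instead, (trifluoromethyl in place of hydroxy on an aromatic carbon), gives a step that the two limits leave unreadable from compound 2 to compound 1, so that step has no readable size.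

Compound 4 `O=S(=O)(Nc1ccc2oc(-c3ccccc3)nc2c1)c1ccccc1C(F)(F)F` is the unmeasured member. It differs from compound 3 by trifluoromethyl in place of hydroxy on an aromatic carbon. This is the same kind of change as from compound 2 to compound 1, not the same: there the place was meta to a large group, here it is ortho to a large group.

For compound 4 in this assay a step of a 1.8-fold higher number from compound 3 to compound 4 (0.26 log units; within the scatter) is expected, with wide uncertainty. The expectation rests on compound 1 and compound 2 both standing at the limit of > 100000 nM in this assay, at which 2 of the 3 values shown sit, which leaves the size of a step that the two limits leave unreadable from compound 2 to compound 1 open. The estimate for compound 4 is 60000 nM, between 20000 nM and 200000 nM.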

Compound 4, half-maximal cytotoxic concentration: 80000 nM
Beside the measured number, compound 4's estimate is 1.3-fold (0.12 log units) below it; low and high end bracket the measured number.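

In this assay, trifluoromethyl in place of hydroxy has a readable size in one pair only, where the place is ortho to a large group: a 2.4-fold higher number from compound 3 to compound 4 (0.38 log units; beyond the scatter). The same exchange in the pair of compound 2 and compound 1 cannot be read, because both compounds stand at a limit and not at a number: the limit of > 100000 nM in this assay, at which 2 of the 4 values shown sit. The two pairs therefore neither confirm nor contradict each other, and this single readable step gives no size that can be carried to another place on the ring or to another core.

Open, as far as these compounds go, is whether the step seen with compound 3 and compound 4 holds anywhere other than this one place on the shared core, since the readable evidence comes from one pair. Also open, from the compounds shown here alone, is how this assay would respond at the same place to a different group, such as an amine, a carboxylic acid or a longer chain.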